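The source may hold more compounds than are shown below. What is called first, only, known or untested is meant among the compounds shown, and "the series" means these compounds.

Measured compounds:
- compound 1, `COc1cc(-c2nnc3n2NC(c2ccco2)C(C(=O)c2ccc(Br)cc2)S3)cc(OC)c1OC`: 42100 nM
- compound 2, `COc1cc(-c2nnc3n2NC(c2ccco2)C(C(=O)c2cccc4ccccc24)S3)cc(OC)c1OC`: > 100000 nM
- compound 3, `COc1ccc(C(=O)C2Sc3nnc(-c4cc(OC)c(OC)c(OC)c4)n3NC2c2ccco2)cc1`: > 100000 nM

All three share one core and differ only in the aryl group attached to the carbonyl. For the measured compounds named here, in a functional assay on A549 cells (Homo sapiens) for cytotoxicity, read by MTT assay, with a stated time of 48 h (a higher number here means a weaker inhibitor, a lower number a stronger inhibitor), compound 1 gives 42100 nM, and this is the only actual number in the set. For compound 2 this assay reports only a limit, > 100000 nM. For compound 3 this assay likewise reports only a limit, > 100000 nM. Going by the values given here, both therefore sit at the limit of > 100000 nM in this assay, at which 2 of the 3 values shown sit, so compound 1 is the one compound here with a measurable effect.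

Compound 4, `COc1cc(-c2nnc3n2NC(c2ccco2)C(C(=O)c2ccc(C(F)(F)F)cc2)S3)cc(OC)c1OC`, is not yet measured. It differs from compound 1 by trifluoromethyl in place of bromo on an aromatic carbon. Among the compounds with values here, two measured steps bear on this: an at least 2.3-fold higher number from compound 1 to compound 2 (0.37 log units; beyond the scatter) and an at least 2.3-fold higher number from compound 1 to compound 3 (0.37 log units; beyond the scatter). Each replaced the bromo-bearing ring or the bromo itself and each pushed the value beyond the limit, so changes at this spot have so far only weakened the effect. The step that the two limits leave unreadable from compound 2 to compound 3, between two limits, adds nothing readable.

On that basis a further weakening is expected for compound 4, on the order of a 1.9-fold higher number from compound 1 to compound 4 (0.28 log units; within the scatter), with a real chance that this assay again reports only a limit. Compound 4 is estimated at 80000 nM, in a range from 30000 nM to 200000 nM.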

Compound 4, half-maximal inhibitory concentration: 37200 nM
Compound 4: middle estimate off by 2.2-fold (0.33 log units), on the high side; the measured number falls inside the stated range.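

Until now, every change at this position had taken the value to the limit of the assay, so it was unclear whether bromo itself was needed for a measurable effect. In this assay, for the compounds shown here, trifluoromethyl in place of bromo gives a 1.1-fold lower number from compound 1 to compound 4 (0.05 log units; within the scatter), so for this one swap the two groups cannot be told apart, and bromo is not the only group on this ring that keeps a measurable value. The swap also sets compound 4 clearly apart from the two compounds without a measurable value, with an at least 2.6-fold lower number from compound 3 to compound 4 (0.42 log units; beyond the scatter) for trifluoromethyl in place of methoxy and an at least 2.6-fold lower number from compound 2 to compound 4 (0.42 log units; beyond the scatter) for 4-(trifluoromethyl)phenyl in place of naphthalen-1-yl, although both of these steps start from a limit of the assay and not from a number: the limit of > 100000 nM in this assay, at which 2 of the 4 values shown sit.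

Going by these compounds alone, compounds 1 and 4 are only one matched pair, so they cannot show what bromo and trifluoromethyl have in common that methoxy lacks. Going by these compounds, whether chloro, a nitrile, an amine or a carboxylic acid in place of bromo would keep a measurable value remains open, as does whether any group here could bring the value much lower.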